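Clearance notes: changing the group on the sulfonyl sulfur

The source may hold more compounds than are shown below. What is called first, only, known or untested is meant among the compounds shown, and "the series" means these compounds.

In an ADME assay on microsomes from liver (Homo sapiens) for pharmacokinetics, read by LC-MS, with a stated time of 60 min, tested at 1 uM (on this read-out higher numbers stand for fast clearance and lower numbers for slow clearance), compound 1 `C[C@@H]1COC[C@@H](C)N1S(=O)(=O)c1ccc(NC(=O)NCc2cccnc2)cc1` gives 17 mL/min/kg, while compound 2 `O=C(NCc1cccnc1)Nc1ccc(S(=O)(=O)N2CCC3(CCNC3)CC2)cc1` gives 4 mL/min/kg, the lower of the two numbers. Compound 3 `O=C(NCc1cccnc1)Nc1ccc(S(=O)(=O)N2CCCNCC2)cc1` keeps the shared core and changes only the group on the sulfonyl sulfur, which becomes 1,4-diazepan-1-yl: a group of 7 heavy atoms (5 carbon, 2 nitrogen; one seven-membered non-aromatic ring with 2 hetero atoms) in place of a group of 10 heavy atoms (8 carbon, 2 nitrogen; one five-membered non-aromatic ring with 1 hetero atom, one six-membered non-aromatic ring with 1 hetero atom), on a sulfonyl sulfur. Among the compounds with values here, one measured step bears on this position, a 4.3-fold lower number from compound 1 to compound 2 (0.63 log units; beyond the scatter). It shows that the number can move with the group on this sulfur, but it gives no direction for a seven-membered ring. The hydrogen-bond donor and acceptor counts stay the same in the new change, so a smaller move than that step is expected, with no clear direction. The estimated result in this assay is a 1.3-fold higher number from compound 2 to compound 3 (0.10 log units; within the scatter), which would stay within the scatter. For compound 3 the expected clearance is 5 mL/min/kg, with an estimated range of 2.5 mL/min/kg to 10 mL/min/kg.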

Compound 3, clearance: 6 mL/min/kg
Compound 3: the middle estimate sits 1.2-fold (0.08 log units) below what was measured, and the stated range covers the measured number.
By their numbers in this assay, from the lowest: compounds 2 and 3 (each within the scatter of the next); then compound 1.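

Going from the group of 10 heavy atoms to 1,4-diazepan-1-yl on the sulfonyl sulfur, a change of ring type and size, gives no readable difference in this assay (a 1.5-fold higher number from compound 2 to compound 3 (0.18 log units; within the scatter)). Replacing 3,5-dimethylmorpholin-4-yl with 1,4-diazepan-1-yl gives a second step beyond the scatter (a 2.8-fold lower number from compound 1 to compound 3 (0.45 log units; beyond the scatter)), so among these three compounds the lower numbers now belong to two different groups rather than to the two-ring group alone. Nothing at hand accounts for these numbers.

On these data alone, it remains open whether piperazin-1-yl or an open-chain amine on the sulfonyl sulfur would fall with compound 2 and compound 3 or with compound 1. Also open, as far as these compounds go, is whether plain morpholin-4-yl, without the two methyl groups, would stay with compound 1.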